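Shifting Fluorine on a Benzyl Group

This account rests on a few compounds, and the source may have more. Where it says the series, first, only, none or still open, it means among the compounds named here.

Compound 1, `Cc1ccc2c(NCc3ccc(NC(=O)C4CCN(C5CCCCC5)CC4)cc3)nc(N(C)C)nc2c1`, in a functional assay on SV5A8 cells (Homo sapiens) for cytotoxicity; a higher number here means a weaker inhibitor, a lower number a stronger inhibitor: > 8320 nM, a limit only.
Compound 2, `Cc1ccc2c(NCc3ccc(NC(=O)C4CCN(Cc5ccccc5F)CC4)cc3)nc(N(C)C)nc2c1`, in this assay: > 6670 nM, a limit only.

Both measured values are limits of the assay, not numbers. Compound 2 therefore stands only at a limit, and the step that the two limits leave unreadable from compound 1 to compound 2 cannot be read. Compound 3, `Cc1ccc2c(NCc3ccc(NC(=O)C4CCN(Cc5ccc(F)cc5)CC4)cc3)nc(N(C)C)nc2c1`, differs from compound 2 in one place: 4-fluorophenyl in place of 2-fluorophenyl on a saturated chain carbon bound to an amine nitrogen in a ring. Among the measured compounds shown here, no measured step bears on this change, so no direction beyond the scatter is expected. Compound 3 is expected to give 10000 nM, within 4000 nM to 30000 nM, most likely again as a limit. The expected step is a step that the limit leaves unreadable from compound 2 to compound 3.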

Compound 3, half-maximal inhibitory concentration: > 4820 nM
Compound 3 was reported as a limit; the forecaster's own chance of this, stated with the estimate: 80%; the middle value is on the limit's open side.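

Among the compounds shown here, compound 3, like compound 1 and compound 2, stands only as a limit, so no step among the three can be read. The compounds shown leave open whether 4-fluorobenzyl and 2-fluorobenzyl differ at all in this assay.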